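Working notes: from dimethylamino to bromo in compound 3

This account rests on a few compounds, and the source may have more. Where it says the series, first, only, none or still open, it means among the compounds named here.

Values in a functional assay on HeLa cells (Homo sapiens) for inhibition, read by MTT assay, with a stated time of 48 h; on this read-out lower numbers stand for stronger inhibition and higher numbers for weaker inhibition:
- compound 1 `Oc1cccc(C(c2c[nH]c3ccc(Br)cc23)c2c[nH]c3ccc(Br)cc23)c1`: 3900 nM
- compound 2 `CN(C)c1ccc(C(c2c[nH]c3ccc(Br)cc23)c2c[nH]c3ccc(Br)cc23)cc1`: 12800 nM

Among the measured compounds shown here, compound 2 holds the higher of the two numbers in this assay, and compound 1 is its only neighbour. The next compound, compound 3 `Brc1ccc(C(c2c[nH]c3ccc(Br)cc23)c2c[nH]c3ccc(Br)cc23)cc1`, carries bromo in place of dimethylamino on an aromatic carbon, para to a large group: bromo in place of dimethylamino on an aromatic carbon. For the measured compounds named here, the one measured step that bears on this change is a 3.3-fold higher number from compound 1 to compound 2 (0.52 log units; beyond the scatter), a modest step beyond the scatter, with 4-(dimethylamino)phenyl in place of 3-hydroxyphenyl. Going by the values given here, no measured compound carries bromo at this place, so this single step is a weak guide. A step of similar modest size towards a lower number is expected, though one within the scatter remains possible. The estimate in this assay means a 2.1-fold lower number from compound 2 to compound 3 (0.33 log units; beyond the scatter). For compound 3 the expected value is 6000 nM, with an estimated range from 2000 nM to 18000 nM.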

Compound 3, half-maximal inhibitory concentration: 1500 nM
The estimate for compound 3 lay 4.0-fold (0.60 log units) above the measured number; the measured number lies below the stated range.
By their numbers in this assay, from the lowest: compound 3; then compound 1; then compound 2.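

In this assay, bromo in place of dimethylamino gives an 8.5-fold lower number from compound 2 to compound 3 (0.93 log units; beyond the scatter) and is a larger step than the earlier change at the aryl group suggested. The 4-bromophenyl group also improves on 3-hydroxyphenyl, with a 2.6-fold lower number from compound 1 to compound 3 (0.41 log units; beyond the scatter) and both steps beyond the scatter, so compound 3 has the lowest number of the three and the aryl substituent clearly affects this read-out. Nothing at hand gives a reason for either step.

Still open, going by these compounds, is whether the lower number is specific to bromo or would also appear with chloro, fluoro, methyl or a carboxylic acid at this place. The compounds shown also leave open how 3-bromophenyl compares with 4-bromophenyl, since substituent and placement both differ between compound 1 and compound 3.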